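The source may report more compounds than this note shows. Statements on the series, on what has been measured and on what is new or still open speak of the compounds shown alone.

Measured so far:
- Compound 1 `Cc1nc(-c2ccccc2F)c(C(=O)N2CCN(c3cc(Cl)cc(Cl)c3)CC2)s1`: 157 nM
- Compound 2 `COc1cccc(N2CCN(C(=O)c3oc(C)nc3-c3ccccc3F)CC2)c1`: 56.1 nM
- Compound 3 `Cc1ccc(C)c(N2CCN(C(=O)c3oc(C)nc3-c3ccccc3Cl)CC2)c1`: > 1000 nM

These values come from a functional assay on HL-60 cells (Homo sapiens) for inhibition, read by MTT assay, with a stated time of 72 h; a lower number here means a stronger inhibitor, a higher number a weaker inhibitor. The entry for compound 3, > 1000 nM, is a limit and not a number. Of the two true numbers, compound 2 has the lower, 56.1 nM, and the gap to compound 1 lies beyond the scatter.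

Compound 4 `COc1cc(OC)cc(N2CCN(C(=O)c3oc(C)nc3-c3ccccc3F)CC2)c1` differs from compound 2 by methoxy in place of hydrogen on an aromatic carbon, which turns 3-methoxyphenyl into 3,5-dimethoxyphenyl. For the measured compounds named here, no two measured compounds differ in just one place, so the effect of this change has not been seen directly. The expected step of a 1.6-fold higher number from compound 2 to compound 4 (0.21 log units; within the scatter) is modest, towards a weaker inhibitor, and may stay within the scatter. Compound 4 is estimated at 90 nM, with an expected range of 28 nM to 350 nM.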

Compound 4, half-maximal inhibitory concentration: 10.3 nM
Compound 4: middle estimate off by 8.7-fold (0.94 log units), on the high side; the whole stated range lies above it.
By their numbers in this assay, from the lowest: compound 4; then compound 2; then compound 1. At a limit, above all of these: compound 3.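

This is the first pair among the compounds shown that differs in only one place, so the effect of a single change can finally be read. Turning 3-methoxyphenyl into 3,5-dimethoxyphenyl gives a 5.4-fold lower number from compound 2 to compound 4 (0.74 log units; beyond the scatter) and makes the inhibitor stronger, not weaker. This aromatic carbon, meta to a large group and meta to a methoxy group, therefore accepts a methoxy group and responds strongly to it.

Going by these compounds, whether a hydroxy group, an amine or a longer ether chain at this carbon would act the same way stays open. Nothing given here accounts for the size of this step.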